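Fluoro on the pyridine ring and BV-2 cytotoxicity

The source may hold more compounds than are shown below. What is called first, only, known or untested is meant among the compounds shown, and "the series" means these compounds.

Measured compounds:
compound 1, `COc1cccc(S(=O)(=O)/C=C/c2ccccn2)c1`, 100%
compound 2, `COc1cccc(S(=O)(=O)/C=C/c2ncccc2F)c1`, 100%
compound 3, `COc1ccc(S(=O)(=O)/C=C/c2cccnc2)cc1`, 99.5%

The three measured compounds were tested in an ADME assay on BV-2 cells (Mus musculus) for cytotoxicity, with a stated time of 24 h, tested at 10 uM; a lower number here means a stronger effect, a higher number a weaker effect of the compound at the concentration tested. In this assay compound 1 gives 100%, compound 2 gives 100% and compound 3 gives 99.5%. All three numbers sit within the scatter of one another, so none of them can be called stronger or weaker than the others.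

Compound 2 arises from compound 1 by fluoro in place of hydrogen on an aromatic carbon; the step that this change made is no change at the digits printed from compound 1 to compound 2 (within the scatter). Compound 4, `COc1ccc(S(=O)(=O)/C=C/c2ccc(F)nc2)cc1`, is not yet measured; it arises from compound 3 by fluoro in place of hydrogen on an aromatic carbon. The place of the entering group is not the same word for word in the two cases: in compound 2 it sits ortho to a large group and two atoms from the ring nitrogen, in compound 4 next to the ring nitrogen and para to a large group. The two changes are therefore of the same kind, not the same. How the core of compound 3 differs from the core of compound 1 is not broken down here, the two having the same atoms joined differently.

Since the step from compound 1 to compound 2 stayed within the scatter, the step from compound 3 to compound 4 in this assay is expected to be a number 0.5 percentage points lower from compound 3 to compound 4 (within the scatter) as well. For compound 4 the estimate in this assay is 99%, with an expected range from 90% to 104%.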

Compound 4, a percentage reported as activity, at one concentration (the size of the read-out at that concentration, not a potency): 100%
Estimate against measurement, compound 4: 1 percentage points below; the measured number falls inside the stated range.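

In this assay, fluoro in place of hydrogen on an aromatic carbon gave a number 0.5 percentage points higher from compound 3 to compound 4 (within the scatter), and set beside the earlier step, the change behaved alike on the two cores: the same change on two cores in this assay, no change at the digits printed (within the scatter) from compound 1 to compound 2 and a number 0.5 percentage points higher (within the scatter) from compound 3 to compound 4, 0.5 percentage points apart, within the scatter of two such steps. The change therefore carried from the core of compound 1 to the core of compound 3 without a step beyond the scatter on either, even though the fluoro does not occupy the same place in compound 2 and compound 4. This does not show that the two cores would respond alike in general, since the evidence is just two steps at a single tested concentration, neither of them beyond the scatter, and it cannot say how the change would behave on a core where the starting compound had a clear effect in this read-out.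

The compounds shown differ in these steps only by hydrogen or fluoro on the pyridine ring, so it remains open whether a larger or different group there, such as chloro, an amine or a carboxylic acid, would also stay within the scatter. Also open, from the compounds shown here alone, is whether a longer chain in place of the methoxy group would leave the read-out where these four compounds stand.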